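Diselenol cores and an amino-for-selenium replacement

A few compounds are considered here, and "the series" means these few. Any claim that something is new, unique, unknown or untested is made for them only; others in the source may bear on it.

Three compounds have numbers in an ADME assay on 184B5 cells (Homo sapiens) for cytotoxicity, read by MTT assay, with a stated time of 72 h; a higher number here means a weaker inhibitor of growth, a lower number a stronger inhibitor of growth. Compound 1 `[SeH]c1nc([SeH])c2ccccc2n1` gives 2500 nM in this assay. Compound 3 `[SeH]c1nc([SeH])c2cccnc2n1` gives 8260 nM, and compound 2 `Nc1nc([SeH])nc2ncccc12` gives 31100 nM, both in this assay. The difference between the cores of compound 1 and compound 3 is not broken down here. The change from compound 3 to compound 2 is one nitrogen atom in place of one selenium atom, on an aromatic carbon; in this assay it made a 3.8-fold higher number from compound 3 to compound 2 (0.58 log units; beyond the scatter). Compound 4 `Nc1nc([SeH])nc2ccccc12` stands to compound 1 as compound 2 stands to compound 3: the change is one nitrogen atom in place of one selenium atom, on an aromatic carbon, the same change at the same place. Only one worked example of this change exists, so the step from compound 1 to compound 4 is expected to be a 3.8-fold higher number from compound 1 to compound 4 (0.58 log units; beyond the scatter). This expectation rests on compound 3 and compound 2, where the change made a 3.8-fold higher number from compound 3 to compound 2 (0.58 log units; beyond the scatter). Compound 4 is therefore estimated at 9500 nM in this assay, between 4000 nM and 24000 nM.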

Compound 4, concentration for total growth inhibition: 36700 nM
Estimate against measurement, compound 4: 3.9-fold (0.59 log units) below; measured number above the stated range.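

In this assay, amino in place of selenium gives a 15-fold higher number from compound 1 to compound 4 (1.17 log units; beyond the scatter) on the core of compound 1. The direction of the change holds on both cores, but its size does not carry over: the same change on two cores in this assay, a 3.8-fold higher number (0.58 log units; beyond the scatter) from compound 3 to compound 2 and a 15-fold higher number (1.17 log units; beyond the scatter) from compound 1 to compound 4, 3.9-fold (0.59 log units) apart, beyond the scatter of two such steps. Among these compounds, with only two pairs, this shows that a step measured on one core is a poor guide to the size of the step on the other, but it does not show what in the cores sets that size or how the change would run on a third core.

Still open, going by these compounds, is whether the remaining selenium can be replaced with a similar result. Also open, on these data alone, is how a hydroxyl, a methyl or a methylamino group at the same place compares with amino.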